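A few compounds are considered here, and "the series" means these few. Any claim that something is new, unique, unknown or untested is made for them only; others in the source may bear on it.

Solubility readings across the series, all in a physicochemical assay for solubility, read by LC-MS, in phosphate buffer, with a stated time of 24 h, at pH 7.4; a higher number here means a more soluble compound, a lower number a less soluble compound:

- compound 1, `Cn1cc(-c2cnc(NCc3c(F)ccc4c3CCO4)c3cn[nH]c(=O)c23)cn1`: 1000 nM
- compound 2, `CN(C)Cc1ccc2c(c1)CN(c1cnc(NCc3c(F)ccc4c3CCO4)c3cn[nH]c(=O)c13)C2=O`: 174000 nM
- compound 3, `Cc1ncccc1-c1cnc(NCc2c(F)ccc3c2CCO3)c2nn(CC#N)c(=O)n12`: 4000 nM

Among these three numbers compound 1 stands lowest. The nearest of the other two is compound 3, whose number is higher by a gap that lies beyond the scatter of this assay; the furthest is compound 2, whose number is higher by a gap far beyond the scatter. For the measured compounds named here, no pair of these measured compounds differs in only one place, so no single-change step can be read from them; the spread only shows that changes at the position carrying the pyrazole of compound 1 can move solubility over a wide span.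

Compound 4, `CC(=O)N1CCC(c2cnc(NCc3c(F)ccc4c3CCO4)c3cn[nH]c(=O)c23)CC1`, is not yet measured. It differs from compound 1 in one place: 1-acetylpiperidin-4-yl in place of 1-methyl-1H-pyrazol-4-yl on an aromatic carbon. Going by the values given here, with no measured step of this kind to lean on, the expectation is a moderate upward step in this assay, larger than the usual scatter but well short of the gap that separates compound 2 from compound 1. The estimated step is a 10-fold higher number from compound 1 to compound 4 (1.00 log units; beyond the scatter). Compound 4 is expected to give 10000 nM, within a range of 2500 nM to 40000 nM.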

Compound 4, solubility: < 2000 nM
Compound 4 was reported as a limit; the forecaster's own chance of this, stated with the estimate: 5%; at least 5.0-fold (0.69 log units) between middle value and limit.
By their numbers in this assay, from the lowest: compound 1; then compound 3; then compound 2.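

In this assay compound 4 gives < 2000 nM, which is a limit and not a number. For the compounds shown here, no step between compound 1 and compound 4 can be read from it: the limit of < 2000 nM in this assay, at which 1 of the 4 values shown sits. The compounds shown leave open how 1-acetylpiperidin-4-yl in place of 1-methyl-1H-pyrazol-4-yl moves the reading in this assay, in direction or in size.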